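Aryl ether swap on the ether oxygen, stability outlook

The source may report more compounds than this note shows. Statements on the series, on what has been measured and on what is new or still open speak of the compounds shown alone.

Compound 2 `C=CC(=O)NCc1coc(-c2c(N)ncnc2Nc2ccc(Oc3cccc(F)c3)c(Cl)c2)n1` carries a 3-fluorophenyl on the ether oxygen of the shared core. In an in vitro ADME assay on microsomes from liver (Rattus norvegicus) for metabolic stability, tested at 5 uM (a higher number here means that the compound lasts longer, a lower number that the compound disappears faster), compound 2 gives 0.9 h, and compound 1 `C=CC(=O)NCc1coc(-c2c(N)ncnc2Nc2ccc(Oc3cc(Cl)ccc3Cl)c(Cl)c2)n1` gives 0.85 h in this assay; the two numbers lie within the scatter of each other, so compound 2 cannot be set apart from compound 1 on these data. Among the compounds with values here, the only step that varies the aryl group on that oxygen, a 1.1-fold higher number from compound 1 to compound 2 (0.02 log units; within the scatter), is within the scatter. Compound 3 `C=CC(=O)NCc1coc(-c2c(N)ncnc2Nc2ccc(Oc3ccccn3)c(Cl)c2)n1` differs from compound 2 by pyridin-2-yl in place of 3-fluorophenyl on an oxygen on an aromatic ring. Within the data shown here, the single measured step at this position was flat, and nothing measured here separates a pyridin-2-yl from a 3-fluorophenyl at that place, so no step beyond the scatter is expected in this assay. The step expected from compound 2 to compound 3 is no change at the digits printed from compound 2 to compound 3 (within the scatter). For compound 3 the estimated half-life in this assay is 0.9 h, with a range from 0.45 h to 1.8 h.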

Compound 3, half-life: 0.267 h
For compound 3 the middle estimate is 3.4-fold (0.53 log units) above the measured one, and the stated range ends above it.
By their numbers in this assay, from the lowest: compound 3; then compounds 1 and 2 (each within the scatter of the next).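

The aryl group on the ether oxygen is not a silent place in this assay: pyridin-2-yl gives a lower half-life than either aryl group before it (a 3.4-fold lower number from compound 2 to compound 3 (0.53 log units; beyond the scatter); a 3.2-fold lower number from compound 1 to compound 3 (0.50 log units; beyond the scatter)). The earlier step between the 2,5-dichlorophenyl and the 3-fluorophenyl stayed within the scatter, so among these three compounds the split lies between the two rings of carbon only and the ring with a hetero atom, and no compound goes against it. Nothing available here accounts for the lower half-life of compound 3.

Still open, going by these compounds, is whether the lower number follows the ring nitrogen itself, its place in the ring, or the loss of halogen from the ring. A plain phenyl, a pyridin-3-yl or a pyridin-4-yl on the same oxygen would separate these readings.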